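A few compounds are considered here, and "the series" means these few. Any claim that something is new, unique, unknown or untested is made for them only; others in the source may bear on it.

Series notes. Compound 1 `Cc1ccc(S(=O)(=O)n2cc(CNCc3cccc(F)c3F)c3ccccc32)cc1` gives 46% in a functional assay on 3T3-L1 cells (Mus musculus) for inhibition, with a stated time of 20 min, tested at 20 uM; a lower number here means less inhibition, a higher number more inhibition at the concentration tested (going by the name of the read-out). Compound 2 `CC(=O)N(Cc1cccc(F)c1F)Cc1cn(S(=O)(=O)c2ccc(C)cc2)c2ccccc12` gives 57.5% in this assay, and compound 2 stands highest of the two numbers measured, with compound 1 the nearer and the only other point. Within the data shown here, the one measured step, a number 11.5 percentage points higher from compound 1 to compound 2 (beyond the scatter), is the only guide within this set: acetyl in place of hydrogen on an amine nitrogen raised inhibition by a modest amount, beyond the scatter.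

Compound 3 `Cc1ccc(S(=O)(=O)n2cc(CN(Cc3cccc(F)c3F)S(C)(=O)=O)c3ccccc32)cc1` differs from compound 2 by methylsulfonyl in place of acetyl on an amine nitrogen. The change again alters the group on the amine nitrogen, but it swaps one acyl-type substituent for another rather than adding one to a bare nitrogen, so the measured step from compound 1 to compound 2 bears on it only loosely. Among the measured compounds shown here, no step comparing acetyl with methylsulfonyl is available. The expectation is therefore no step beyond the scatter in this assay, in either direction, with a number 0.5 percentage points higher from compound 2 to compound 3 (within the scatter) as the estimated change from compound 2 to compound 3. Compound 3 is estimated at 58% in this assay, within a range of 40% to 75%.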

Compound 3, a percentage reported as inhibition, at one concentration (the size of the read-out at that concentration, not a potency): -3.3%
Beside the measured number, compound 3's estimate is 61.3 percentage points above it, and the stated range ends above it.
By their numbers in this assay, from the lowest: compound 3; then compound 1; then compound 2.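

In this assay, the group on the amine nitrogen now proves to control the read-out far more strongly than the earlier pair could show: exchanging acetyl for methylsulfonyl gives a large fall (a number 60.8 percentage points lower from compound 2 to compound 3 (beyond the scatter)), and methylsulfonyl also stands well under the bare nitrogen (a number 49.3 percentage points lower from compound 1 to compound 3 (beyond the scatter)). Substitution at this position therefore has no single direction across the three compounds, since acetyl gives a modest rise (a number 11.5 percentage points higher from compound 1 to compound 2 (beyond the scatter)) while methylsulfonyl gives a large fall from the same starting point. The data offer no explanation for this split between two substituents on the same nitrogen.

From the compounds shown here alone, it remains open whether the fall belongs to the sulfonyl group as such or to this particular methylsulfonyl, a question that an ethylsulfonyl or phenylsulfonyl group at the same nitrogen would help to settle. Going by these compounds, it is equally open whether the gain seen with acetyl extends to a longer acyl chain such as propionyl, or to a urea or a methyl carbamate in its place.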